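The compounds below may be only part of what the source reports. "The series", "measured", "known", "first", "only" and "open" are said of these compounds alone.

Measured compounds:
- compound 1 `CC(C)C[C@H](O)C(=O)NS(=O)(=O)OC[C@H]1O[C@@H](n2cnc3c(N)ncnc32)[C@H](O)[C@@H]1O` — 1000 nM
- compound 2 `CO[C@H](C(=O)NS(=O)(=O)OC[C@H]1O[C@@H](n2cnc3c(N)nc(Cl)nc32)[C@H](O)[C@@H]1O)[C@H](OC)C(C)C` — > 20000 nM
- compound 3 `CC(C)C[C@H](O)C(=O)NS(=O)(=O)OC[C@H]1O[C@@H](n2cnc3c(=O)[nH]cnc32)[C@H](O)[C@@H]1O` — > 20000 nM

In a functional assay on A549 cells (Homo sapiens) for antiproliferative activity, read by sulforhodamine B assay, with a stated time of 72 h (on this read-out lower numbers stand for stronger inhibition and higher numbers for weaker inhibition), compound 1 gives 1000 nM. For compound 2 the value > 20000 nM is a limit of this assay, not a number. For compound 3 the value > 20000 nM is likewise a limit. For the measured compounds named here, the single step measured in one place is an at least 20-fold higher number from compound 1 to compound 3 (1.30 log units; beyond the scatter); both limits sit at the limit of > 20000 nM in this assay, at which 2 of the 3 values shown sit.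

Compound 4 `CC(C)C[C@H](Cl)C(=O)NS(=O)(=O)OC[C@H]1O[C@@H](n2cnc3c(N)nc(Cl)nc32)[C@H](O)[C@@H]1O` is reached from compound 2 by a group of 6 heavy atoms (5 carbon, 1 chlorine; no ring) in place of a group of 9 heavy atoms (7 carbon, 2 oxygen; no ring), on a carbonyl carbon. Going by the values given here, this change sits on the acyl side, whereas the one measured step concerns the base, so no measured step bears directly on it; compound 2 itself stands at a limit, which leaves the size of any step from it open in this assay. The base of compound 4 is that of compound 2, and compound 1, with a different base and a hydroxyl-bearing chain, gives 1000 nM.

Compound 4 is therefore expected to land around 8000 nM, with a range of 1500 nM to 20000 nM, which would mean an estimated at least 2.5-fold lower number from compound 2 to compound 4 (0.39 log units; beyond the scatter).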

Compound 4, half-maximal inhibitory concentration: 6270 nM
Beside the measured number, compound 4's estimate is 1.3-fold (0.11 log units) above it; the range from low to high includes it.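

For the compounds shown here, replacing the group of 9 heavy atoms with the group of 6 heavy atoms on a carbonyl carbon gives, in this assay, an at least 3.1-fold lower number from compound 2 to compound 4 (0.50 log units; beyond the scatter), the first measured change on the acyl side; the earlier at least 20-fold higher number from compound 1 to compound 3 (1.30 log units; beyond the scatter) concerned the base. Compound 4 gives 6270 nM as a measured number, so the base it shares with compound 2 does not by itself rule out a measured number. The true size of this step stays unknown because the value of compound 2 is a limit: the limit of > 20000 nM in this assay, at which 2 of the 4 values shown sit.

Compounds 1 and 4 differ in more than one place, so the separate contributions of the base and the chain remain unresolved. Also open, on these data alone, is whether an amine or a longer chain in this position would lower the number further than the chlorine-bearing group.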